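The compounds below may be only part of what the source reports. "The series", "measured", "known", "first", "only" and "open" are said of these compounds alone.

Measured so far in a functional assay with Alpha-1A adrenergic receptor (Homo sapiens) as the target, read by calcium flux; on this read-out lower numbers stand for smaller maximal responses and higher numbers for larger maximal responses:
compound 1 `Cc1ccc(-c2ccccc2NCC2=NCCN2)n1C` gives 78%
compound 2 `Cn1cccc1-c1ccccc1NCC1=NCCN1` gives 103%
compound 3 `CCCn1nccc1-c1ccccc1NCC1=NCCN1` gives 59%

Compound 2 holds the highest of the three numbers; compound 1 lies nearest and compound 3 furthest, both gaps beyond the scatter. The change from compound 2 to compound 4 `Cn1ncnc1-c1ccccc1NCC1=NCCN1` is 1-methyl-1H-1,2,4-triazol-5-yl in place of 1-methyl-1H-pyrrol-2-yl on an aromatic carbon. Within the data shown here, the only measured step, a number 25 percentage points higher from compound 1 to compound 2 (beyond the scatter), concerns hydrogen in place of methyl and does not bear on an exchange of the five-membered ring; no measured pair shows such an exchange. Compound 3, whose five-membered ring also differs from that of compound 2, sits well under compound 2, so a drop is taken as the more likely outcome, though with wide uncertainty. The expected step in this assay is a number 28 percentage points lower from compound 2 to compound 4 (beyond the scatter). The estimate for compound 4 is 75%, range 45% to 105%.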

Compound 4, largest response reached (reported as maximal response), in percent of the reference or control that the assay uses: 91%
The estimate for compound 4 lay 16 percentage points below the measured number; low and high end bracket the measured number.
By their numbers in this assay, from the lowest: compound 3; then compound 1; then compound 4; then compound 2.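

In this assay, 1-methyl-1H-1,2,4-triazol-5-yl in place of 1-methyl-1H-pyrrol-2-yl gives a number 12 percentage points lower from compound 2 to compound 4 (beyond the scatter), the only exchange of the five-membered ring shown as a single change. At this aromatic carbon, a ring with 3 hetero atoms therefore lowers the maximal response modestly without abolishing it. Nothing measured here accounts for the step.

A single pair cannot show whether the response follows the number of hetero atoms in the ring. Still open, going by these compounds, is how a pyridyl ring, or an amine or carboxylic acid on the five-membered ring, would behave at this position.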